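The source may report more compounds than this note shows. Statements on the series, on what has been measured and on what is new or still open speak of the compounds shown alone.

Measured so far in a functional assay on NCI-H460 cells (Homo sapiens) for cytotoxicity, read by MTT assay; a higher number here means a weaker inhibitor, a lower number a stronger inhibitor:
- compound 1, `COc1cccc(/C=C/C(=O)c2sc(Nc3ccc(Cl)cc3)nc2C)c1`: > 25000 nM (a limit of the assay, not a number)
- compound 2, `COc1cccc(/C=C/C(=O)c2sc(Nc3ccccc3)nc2C)c1`: > 25000 nM (a limit of the assay, not a number)

Compound 2 stands at the limit only: in this assay compound 2 gives > 25000 nM, and no number is known for it. Among the measured compounds shown here, the single measured step, a step that the two limits leave unreadable from compound 1 to compound 2, gives no size either, because the limit of > 25000 nM in this assay, at which 2 of the 2 values shown sit, holds both values shown.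

Compound 3, `Cc1nc(Nc2ccccc2)sc1C(=O)/C=C/c1ccccc1Cl`, differs from compound 2 by 2-chlorophenyl in place of 3-methoxyphenyl on a double-bonded chain carbon bound to a double-bonded chain carbon. For the measured compounds named here, no measured step touches this part of the structure; the one measured step alters a different ring, and it is itself unreadable. There is therefore no scale from which to read a size or a direction for the change from compound 2 to compound 3.

With both measured values sitting at the limit, compound 3 is expected to return a limit again in this assay, estimated at 30000 nM with a range of 8000 nM to 100000 nM. The step this estimate implies, a step that the limit leaves unreadable from compound 2 to compound 3, is expected to be none beyond the scatter, with a real number for compound 3 seen as the less likely outcome.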

Compound 3, half-maximal inhibitory concentration: > 25000 nM
Compound 3 ended at the assay's limit (the forecaster's own chance of this, stated with the estimate: 70%); the middle value lies beyond the limit too.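

In this assay compound 3 gives > 25000 nM, which is a limit and not a number. No size or direction can therefore be read for the change from compound 2 to compound 3, because the series sits wholly at one value: the limit of > 25000 nM in this assay, at which 3 of the 3 values shown sit.

The compounds shown leave open whether any change to the shared core yields a real number in this assay.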